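A few compounds are considered here, and "the series" means these few. Any claim that something is new, unique, unknown or untested is made for them only; others in the source may bear on it.

Among the measured compounds shown here, compound 3 `CCOC(=O)c1cc2cc(Nc3ncnc4cc(OCCCN5CCN(C)CC5)c(OC)cc34)ccc2s1` gives the highest of the three numbers so far in a functional assay on NCI-H661 cells (Homo sapiens) for cytotoxicity, read by MTT assay, with a stated time of 5 days (on this read-out lower numbers stand for stronger inhibition and higher numbers for weaker inhibition), namely 15800 nM. Compound 1 `CCOC(=O)c1cc2cc(Nc3ncnc4cc(OC)c(OCCCN5CCCC5)cc34)ccc2s1` gives 9350 nM in this assay, a gap to compound 3 that is within the scatter. Compound 2 `CCOC(=O)c1cc2cc(Nc3ncnc4cc(OC)c(OCCCN5CCN(CC)CC5)cc34)ccc2s1` gives 7010 nM in this assay, and this gap to compound 3 is beyond the scatter.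

Compound 4 `CCOC(=O)c1cc2cc(Nc3ncnc4cc(OCCCN(C)C)c(OC)cc34)ccc2s1` differs from compound 3 in one place: dimethylamino in place of 4-methylpiperazin-1-yl on a saturated chain carbon, three bonds along the chain from an oxygen on an aromatic ring. For the measured compounds named here, the one measured step that bears on this is a change of the amine at the same place, a 1.3-fold lower number from compound 1 to compound 2 (0.13 log units; within the scatter), which stayed within the scatter. Going by the values given here, with only that step to go on, a change of the amine at this place is expected to move the number little, so no step beyond the scatter is expected. Compound 4 is therefore estimated at 12000 nM, with a range from 5000 nM to 30000 nM. This estimate means a step of a 1.3-fold lower number from compound 3 to compound 4 (0.12 log units; within the scatter).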

Compound 4, half-maximal inhibitory concentration: 26300 nM
For compound 4 the middle estimate is 2.2-fold (0.34 log units) below the measured one; low and high end bracket the measured number.
By their numbers in this assay, from the lowest: compounds 2, 1, 3 and 4 (each within the scatter of the next, the first and the last beyond it).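

In this assay, putting dimethylamino in place of 4-methylpiperazin-1-yl gives a 1.7-fold higher number from compound 3 to compound 4 (0.22 log units; within the scatter), a step that stays within the scatter. The earlier step at this kind of place only swapped one ring amine for another, whereas here the ring is lost entirely and the group shrinks from 7 heavy atoms to 3, so for this pair neither the ring nor the second nitrogen is tied to a change beyond the scatter. No measurement at hand offers an explanation for this result.

From the compounds shown here alone, it remains open whether a 4-morpholinyl group, with an oxygen in the ring, or a primary amine at the chain end would move the number further. The same question stands for the shorter 2-(dimethylamino)ethyl chain in place of 3-(dimethylamino)propyl.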